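The compounds below may be only part of what the source reports. "The series", "measured", "known", "first", "only" and "open" are said of these compounds alone.

Measured compounds and their numbers in a functional assay on A549 cells (Homo sapiens) for cytotoxicity, read by MTT assay, with a stated time of 24 h; on this read-out higher numbers stand for weaker inhibition and lower numbers for stronger inhibition:

compound 1 `COc1cccc(-n2cc(COc3c(/C=C\C(=O)O)ccc(OC)c3CC=C(C)C)nn2)c1`: 42700 nM
compound 2 `COc1ccc(/C=C\C(=O)O)c(OCc2cn(-c3cccc(C#N)c3)nn2)c1CC=C(C)C`: "not determined" (no result reported)
compound 3 `COc1ccc(-n2cc(COc3c(/C=C\C(=O)O)ccc(OC)c3CC=C(C)C)nn2)cc1`: 10200 nM

Compound 2 therefore stands nowhere on the numbers shown; the only quantified pair is compound 1 against compound 3, where a 4.2-fold lower number from compound 1 to compound 3 (0.62 log units; beyond the scatter). That step moves a methoxy group around the phenyl ring on the aromatic nitrogen and is modest though beyond the scatter.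

Compound 4 `COc1ccc(/C=C\C(=O)O)c(OCc2cn(-c3ccccc3C#N)nn2)c1CC=C(C)C` differs from compound 2 by 2-cyanophenyl in place of 3-cyanophenyl on an aromatic nitrogen. This is again a repositioning of a single substituent on the phenyl ring at the aromatic nitrogen, so the step between compound 1 and compound 3 is the only one that bears on it, and it shows that such a move can shift the number by a modest amount in either direction. With no number for compound 2, the expectation for compound 4 rests on the band spanned by compound 1 and compound 3 alone, widened for the unknown anchor.

Compound 4 is expected to give about 25000 nM in this assay, with a range of 6000 nM to 100000 nM.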

Compound 4, half-maximal inhibitory concentration: 38600 nM
Beside the measured number, compound 4's estimate is 1.5-fold (0.19 log units) below it, within the range that was stated.
By their numbers in this assay, from the lowest: compound 3; then compounds 4 and 1 (each within the scatter of the next).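

In this assay the aromatic nitrogen also carries 2-cyanophenyl, so this position is no longer probed with methoxyphenyl groups alone. The new compound gives a 3.8-fold higher number from compound 3 to compound 4 (0.58 log units; beyond the scatter) and a 1.1-fold lower number from compound 1 to compound 4 (0.04 log units; within the scatter), which places compound 3 lowest, with steps to both others beyond the scatter, while compound 1 and compound 4 cannot be told apart despite their different substituents. Nothing measured on these compounds accounts for these numbers.

Going by these compounds, the steps involving compound 2 cannot be read, so the effect of 2-cyanophenyl in place of 3-cyanophenyl remains unknown. Also open, on these data alone, is whether 4-cyanophenyl, or an amine at the same place on the phenyl ring, would share the low number of compound 3 or stay with compound 1 and compound 4.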